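Removing one hydroxy group from compound 3

The source may report more compounds than this note shows. Statements on the series, on what has been measured and on what is new or still open speak of the compounds shown alone.

Compound 1 `COc1ccc([C@@H]2[C@H](Oc3ccccc3)C(=O)N2c2cc(OC)c(OC)c(OC)c2)cc1[N+](=O)[O-]`: 69000 nM
Compound 2 `COc1cc([C@@H]2[C@H](Oc3ccccc3)C(=O)N2c2cc(OC)c(OC)c(OC)c2)ccc1O`: 32000 nM
Compound 3 `COc1cc(N2C(=O)[C@@H](Oc3ccccc3)[C@H]2c2ccc(O)c(O)c2)cc(OC)c1OC`: 4500 nM
Compound 4 `COc1cc(N2C(=O)[C@@H](Oc3ccccc3)[C@H]2c2cccc(O)c2)cc(OC)c1OC`: not yet measured

In a functional assay on MCF7 cells (Homo sapiens) for antiproliferative activity, read by MTT assay, with stated times of 24 h and 72 h (on this read-out higher numbers stand for weaker inhibition and lower numbers for stronger inhibition), compound 3 gives the lowest of the three numbers, 4500 nM. Compound 4 has hydrogen in place of hydroxy on an aromatic carbon, turning 3,4-dihydroxyphenyl into 3-hydroxyphenyl: hydrogen in place of hydroxy on an aromatic carbon. Going by the values given here, no measured step removes a hydroxy outright. The closest evidence is a 7.1-fold lower number from compound 2 to compound 3 (0.85 log units; beyond the scatter), alongside a 15-fold lower number from compound 1 to compound 3 (1.19 log units; beyond the scatter) and the smaller 2.2-fold lower number from compound 1 to compound 2 (0.33 log units; beyond the scatter). Both steps arriving at compound 3 lowered the number, so the reverse direction is expected here, at a modest size. The expected change is a 3.3-fold higher number from compound 3 to compound 4 (0.52 log units; beyond the scatter). For compound 4 the estimated value is 15000 nM. The estimated range for compound 4 runs from 5000 nM to 45000 nM.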

Compound 4, half-maximal inhibitory concentration: 54000 nM
Compound 4: the middle estimate sits 3.6-fold (0.56 log units) below what was measured; the whole stated range lies below it.
By their numbers in this assay, from the lowest: compound 3; then compounds 2, 4 and 1 (each within the scatter of the next, the first and the last beyond it).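

Removing the hydroxy ortho to a hydroxy group and para to a large group gives a 12-fold higher number from compound 3 to compound 4 (1.08 log units; beyond the scatter) in this assay and so takes away most of what sets compound 3 apart. The remaining 3-hydroxyphenyl does not hold that level, as compound 4 stays within the scatter of both weaker neighbours (a 1.7-fold higher number from compound 2 to compound 4 (0.23 log units; within the scatter)) and (a 1.3-fold lower number from compound 1 to compound 4 (0.11 log units; within the scatter)). Why this hydroxy counts for so much has no measured explanation here. Open, on these data alone, is whether an amine on this carbon could stand in for the hydroxy, and whether removing the other hydroxy of compound 3 costs as much.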